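The compounds below may be only part of what the source reports. "The series", "measured", "known", "first", "only" and "open" are said of these compounds alone.

Measured so far in this series:
compound 1 `O=C(NCc1ccc(S(=O)(=O)N2CCCCC2)cc1)c1cc2ccncc2[nH]1` — 1000 nM
compound 2 `O=C(NCc1ccc(S(=O)(=O)c2ccccc2)cc1)c1cc2ccncc2s1` — 7 nM
compound 3 `CC(NC(=O)c1cc2cnccc2[nH]1)c1ccc(S(=O)(=O)N2CCCCC2)cc1` — > 10000 nM

In an assay for inhibition of Nicotinamide phosphoribosyltransferase (Homo sapiens), read by mass spectrometry, with stated times of 15 min and 30 min (a lower number here means a stronger inhibitor, a higher number a weaker inhibitor), compound 2 gives 7 nM and stands as the lowest of the two numbers shown. The nearest is compound 1, which in this assay gives 1000 nM, a gap well beyond the usual scatter. Compound 3 reaches only a limit of this assay, > 10000 nM; that is one limit among the three values shown (the limit of > 10000 nM in this assay, at which 1 of the 3 values shown sits), and it is not a number.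

Compound 4 `O=C(NCc1ccc(S(=O)(=O)c2ccccc2)cc1)c1nc2ccncc2s1` has not yet been measured. It differs from compound 2 at the carbonyl carbon: a group of 9 heavy atoms (6 carbon, 2 nitrogen, 1 sulfur; one five-membered aromatic ring with 2 hetero atoms, one six-membered aromatic ring with 1 hetero atom) in place of a group of 9 heavy atoms (7 carbon, 1 nitrogen, 1 sulfur; one five-membered aromatic ring with 1 hetero atom, one six-membered aromatic ring with 1 hetero atom), on a carbonyl carbon. Within the data shown here, no step between measured compounds covers this kind of change, so the expectation rests on compound 2 alone. The expected step in this assay is small, at most modest, and leaning toward a weaker inhibitor rather than a stronger one.

For compound 4 the estimate in this assay is 15 nM, with a range from 4 nM to 60 nM. The step of a 2.1-fold higher number from compound 2 to compound 4 (0.33 log units; beyond the scatter) that this estimate means is expected to lie close to the scatter.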

Compound 4, half-maximal inhibitory concentration: 210 nM
Estimate against measurement, compound 4: 14-fold (1.15 log units) below, outside the stated range (above it).
By their numbers in this assay, from the lowest: compound 2; then compound 4; then compound 1. At a limit, above all of these: compound 3.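

In this assay, the group on the carbonyl carbon proves sensitive to a small change: with 9 heavy atoms on both sides, the exchange of one carbon for one nitrogen gives a 30-fold higher number from compound 2 to compound 4 (1.48 log units; beyond the scatter). The group entering has a five-membered aromatic ring with 2 hetero atoms and 3 hydrogen-bond acceptors, in place of a five-membered aromatic ring with 1 hetero atom and 2 hydrogen-bond acceptors, and the rest of compound 4 matches compound 2, so this single place accounts for the whole step. Nothing measured here bears on why the step is this large.

On these data alone, this change rests on one pair of compounds, so it remains open whether a step of similar size would appear on the core of compound 1. Also open, as far as these compounds go, is how this assay would read for the group of compound 4 carrying an amine or a methyl group, and whether either would bring the number back towards that of compound 2.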